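The source may report more compounds than this note shows. Statements on the series, on what has been measured and on what is new or still open speak of the compounds shown alone.

Compound 2 `Cc1cc(C)cc(Cn2c(=O)cc(NCc3ccccc3)n(Cc3ccccc3)c2=O)c1` is the weaker of the two measured compounds in this series to provoke toxicity: in an ADME assay on MT4 cells (Homo sapiens) for cytotoxicity, read by MTT assay, with a stated time of 4 days (a lower number here means that less compound is tolerated, a higher number that more compound is tolerated), compound 2 gives only a limit of the assay, > 100000 nM, rather than a number (the limit of > 100000 nM in this assay, at which 1 of the 2 values shown sits). Compound 1 `Cc1cc(C)cc(Cn2c(=O)cc(N3CCNCC3)n(Cc3ccccc3)c2=O)c1` gives 16000 nM in this assay. Among the compounds with values here, the single measured step, an at least 6.2-fold higher number from compound 1 to compound 2 (0.79 log units; beyond the scatter), is thus known only as a lower bound.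

Compound 3 `Cc1cc(C)cc(Cn2c(=O)cc(N3CCCC3)n(Cc3ccccc3)c2=O)c1` has not been measured. The change from compound 2 is pyrrolidin-1-yl in place of benzylamino on an aromatic carbon. Within the data shown here, the five-membered non-aromatic ring that enters is closer in kind to the piperazin-1-yl of compound 1 than to the benzylamino of compound 2, so the one measured step bears on it only indirectly, and a value between compound 1 and the limit of compound 2 is expected. Compound 3 is therefore estimated at 60000 nM, within 20000 nM to 150000 nM, an expected step of an at least 1.6-fold lower number from compound 2 to compound 3 (0.22 log units; that floor lies within the scatter).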

Compound 3, half-maximal cytotoxic concentration: 31000 nM
The estimate for compound 3 lay 1.9-fold (0.29 log units) above the measured number, within the range that was stated.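

In this assay, the change from benzylamino to pyrrolidin-1-yl gives an at least 3.2-fold lower number from compound 2 to compound 3 (0.50 log units; beyond the scatter), so a second ring at this position, not only the piperazin-1-yl of compound 1, comes with a number clear of the value for compound 2. Compound 2 itself gives only a limit of the assay, so this step is a bound: the limit of > 100000 nM in this assay, at which 1 of the 3 values shown sits. The exchange of the two rings gives a 1.9-fold higher number from compound 1 to compound 3 (0.29 log units; within the scatter), so this pair does not separate them.

Benzylamino differs from both rings by its benzene ring and by its amine hydrogen, and these compounds cannot say which of the two goes with the higher tolerated concentration. An open-chain amine such as dimethylamino, or a morpholin-4-yl ring, would test whether the ring itself matters at this position.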